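The compounds below may be only part of what the source reports. "The series", "measured", "known", "first", "only" and "open" are said of these compounds alone.

Working notes on the series. The shared core of compound 1 `COCc1cccc2c1CC[C@H]2c1ncc[nH]1` carries a methoxymethyl on the aromatic ring; in a functional assay on CHO cells for agonist activity at Alpha-1A adrenergic receptor (Homo sapiens), read by fluorescence and calcium flux (a higher number here means a larger maximal response, a lower number a smaller maximal response), compound 1 gives 69%. Compound 2 `COCc1c(F)ccc2c1CC[C@H]2c1ncc[nH]1` gives 59% and compound 3 `c1cc(Cn2ccnn2)c2c(c1)C(c1ncc[nH]1)CC2` gives 62%, both within the scatter of compound 1, so no ordering among the three is claimed. Going by the values given here, the one counted step, a number 10 percentage points lower from compound 1 to compound 2 (within the scatter), concerns a different position and does not bear on the present change. Compound 4 `Cc1noc(Cc2cccc3c2CC[C@H]3c2ncc[nH]2)n1` differs from compound 1 by 3-methyl-1,2,4-oxadiazol-5-yl in place of methoxy on a saturated chain carbon bound to an aromatic carbon. Compound 3 shows a comparable change at the same carbon, and its value stays within the scatter of compound 1. No step beyond the scatter is therefore expected: a number 6 percentage points lower from compound 1 to compound 4 (within the scatter). For compound 4 the estimate is 63%, with a range of 50% to 76%.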

Compound 4, largest response reached (Emax), in percent of the reference or control that the assay uses in the Alpha-1A adrenergic receptor assay: 44%
The estimate for compound 4 lay 19 percentage points above the measured number; measured number outside the range, below it.
By their numbers in the Alpha-1A adrenergic receptor assay, from the lowest: compound 4; then compounds 2, 3 and 1 (each within the scatter of the next).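

Going by these compounds alone, on a saturated chain carbon bound to an aromatic carbon, 3-methyl-1,2,4-oxadiazol-5-yl in place of methoxy gives the first step beyond the scatter in the Alpha-1A adrenergic receptor assay: a number 25 percentage points lower from compound 1 to compound 4 (beyond the scatter). In a physicochemical assay for lipophilicity, at pH 7.4 (a lower number here means a more polar compound, a higher number a more lipophilic compound), compound 1 gives 1.8 and compound 4 gives 2, with a number 0.20 log units higher from compound 1 to compound 4 (within the scatter), so only the maximal response separates the pair. Nothing shown accounts for the lower maximal response.

Going by these compounds, whether that response follows the oxadiazole ring itself or any larger group at this carbon stays open; an amine or a longer chain there would bear on this.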